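Methoxy to Fluoro and Tolerated Dose on Vero Cells

This account rests on a few compounds, and the source may have more. Where it says the series, first, only, none or still open, it means among the compounds named here.

Measured compounds:
Compound 1, `CCO/N=C1\C(=O)N(CCCCCOc2ccc3oc(-c4ccc(OC)cc4)c(C(=O)OCC)c3c2)c2ccc(F)cc21`: 32 ug/mL
Compound 2, `CCO/N=C1\C(=O)N(CCCCCOc2ccc3oc(-c4ccc(OC)cc4)c(C(=O)OCC)c3c2)c2ccc(OC)cc21`: 16 ug/mL
Compound 3, `CCOC(=O)c1c(-c2ccc(OC)cc2)oc2ccc(OCCCCCCN3C(=O)C(=O)c4cc(F)ccc43)cc12`: 1020 ug/mL

In an ADME assay on Vero cells (Chlorocebus sabaeus) for cytotoxicity, read by MTT assay, with a stated time of 72 h (a higher number here means that more compound is tolerated, a lower number that less compound is tolerated), compound 1 gives 32 ug/mL and compound 2 gives 16 ug/mL. These two differ in one place only, (fluoro in place of methoxy on an aromatic carbon), and the step is a 2.0-fold higher number from compound 2 to compound 1 (0.30 log units; within the scatter). Compound 3 gives 1020 ug/mL in this assay, a much higher number than either; the difference between the core of compound 3 and the core of compound 2 is not broken down here.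

Compound 4, `CCOC(=O)c1c(-c2ccc(F)cc2)oc2ccc(OCCCCCCN3C(=O)C(=O)c4cc(F)ccc43)cc12`, is not yet measured. It differs from compound 3 by fluoro in place of methoxy on an aromatic carbon. Among the measured compounds shown here, this is the same kind of change as the one from compound 2 to compound 1, but the surroundings differ: there the place is part of a fused or bridged system of two rings, meta to a fused ring and para to a fused ring, whereas here it sits para to a large group on a six-membered aromatic ring of carbon only.

Since the earlier step of a 2.0-fold higher number from compound 2 to compound 1 (0.30 log units; within the scatter) stayed within the scatter, compound 4 is expected to stay close to compound 3, with an estimated step of a 1.3-fold lower number from compound 3 to compound 4 (0.11 log units; within the scatter). For compound 4 the estimate in this assay is 800 ug/mL, expected to fall between 300 ug/mL and 1600 ug/mL.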

Compound 4, half-maximal cytotoxic concentration: 512 ug/mL
For compound 4 the middle estimate is 1.6-fold (0.19 log units) above the measured one; the range from low to high includes it.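

In this assay, swapping methoxy for fluoro on the six-membered aromatic ring of carbon only gives a 2.0-fold lower number from compound 3 to compound 4 (0.30 log units; within the scatter), a step that on its own is small enough to be ordinary scatter. Set beside the same swap on the other core, the two steps point in opposite directions and do not agree: the same change on two cores in this assay, a 2.0-fold higher number (0.30 log units; within the scatter) from compound 2 to compound 1 and a 2.0-fold lower number (0.30 log units; within the scatter) from compound 3 to compound 4, 4.0-fold (0.60 log units) apart, beyond the scatter of two such steps. This shows that the size and direction of a step seen on one core cannot simply be carried over to another in this series, but it does not show what causes the mismatch, since the two pairs differ in their cores and in where the swap sits, and two pairs cannot support a general rule.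

The compounds shown leave open whether the mismatch would recur on a third core, and whether it would also appear with the swap at other places on these cores. They also leave open how other groups on the same aromatic carbon, such as an amine or a carboxylic acid, would behave.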